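The compounds below may be only part of what the source reports. "The series", "measured", "known", "first", "only" and "open" are said of these compounds alone.

Of the compounds shown here, three of a shared core have been measured in a physicochemical assay, at pH 7.4; a lower number here means that the compound disappears faster, a higher number that the compound lasts longer. Compound 1 `CO[C@H]1C(=O)N2C(C(=O)C(C)(C)C)=C(COC(C)=O)CS(=O)(=O)C12` gives 14 h. Compound 2 `CO[C@H]1C(=O)N2C(C(=O)C(C)(C)C)=C(CSc3nnnn3C)CS(=O)(=O)C12` gives 24 h. Compound 3 `CO[C@H]1C(=O)N2C(C(=O)C(C)(C)C)=C(CSc3nnnn3C)[C@@H](Sc3nnnn3C)S(=O)(=O)C12` gives 31 h, the highest of the three numbers, though its gap to compound 2 falls inside the scatter.

Compound 2 and compound 1 differ in one place: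
acetoxy in place of (1-methyl-1H-tetrazol-5-yl)sulfanyl on a saturated chain carbon bound to a double-bonded ring carbon
This change made a 1.7-fold lower number from compound 2 to compound 1 (0.23 log units; within the scatter).

Compound 3 and compound 2 differ elsewhere:
(1-methyl-1H-tetrazol-5-yl)sulfanyl in place of hydrogen on a saturated ring carbon
That change made a 1.3-fold higher number from compound 2 to compound 3 (0.11 log units; within the scatter).

Compound 4 `CO[C@H]1C(=O)N2C(C(=O)C(C)(C)C)=C(COC(C)=O)[C@@H](Sc3nnnn3C)S(=O)(=O)C12` has not been measured. It differs from compound 3 in one place:
acetoxy in place of (1-methyl-1H-tetrazol-5-yl)sulfanyl on a saturated chain carbon bound to a double-bonded ring carbon
This is the same change seen from compound 2 to compound 1, at the same place; the cores differ as described above under the change from compound 2 to compound 3.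

Because the earlier step was a 1.7-fold lower number from compound 2 to compound 1 (0.23 log units; within the scatter), the step from compound 3 to compound 4 is expected to be of similar size, a 1.7-fold lower number from compound 3 to compound 4 (0.24 log units; within the scatter). Compound 4 is therefore estimated to give 18 h in this assay. The expected range for compound 4 runs from 10 h to 33 h.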

Compound 4, half-life: 10 h
The estimate for compound 4 lay 1.8-fold (0.26 log units) above the measured number; the measured number falls inside the stated range.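

In this assay, acetoxy in place of (1-methyl-1H-tetrazol-5-yl)sulfanyl on a saturated chain carbon bound to a double-bonded ring carbon gave a 3.1-fold lower number from compound 3 to compound 4 (0.49 log units; beyond the scatter) and, on the other core, a 1.7-fold lower number from compound 2 to compound 1 (0.23 log units; within the scatter); the direction therefore carried from one core to the other, although only the first step lies beyond the scatter. With acetoxy in place, adding (1-methyl-1H-tetrazol-5-yl)sulfanyl on a saturated ring carbon gave a 1.4-fold lower number from compound 1 to compound 4 (0.15 log units; within the scatter) and so, like the same change on the other core, stayed within the scatter. These two pairs do not show that the size of the step depends on the core or that the direction would hold on any further core, and no measurement at hand explains the result.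

The compounds shown leave open how an amine or a carboxylic acid would behave on that saturated chain carbon. They also leave open whether a longer chain in place of the methyl of the acetoxy group would follow the same direction on both cores.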